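The source may report more compounds than this note shows. Statements on the series, on what has been measured and on what is new or still open speak of the compounds shown alone.

Among the measured compounds shown here, compound 2 `O=c1[nH]cc(S(=O)(=O)Nc2cccc(-c3cn(-c4ccccc4)nn3)c2)c(=O)[nH]1` is the one member of this pair with a number in a functional assay on SGC-7901 cells (Homo sapiens) for antiproliferative activity, read by MTT assay, with a stated time of 24 h (a lower number here means a stronger inhibitor, a higher number a weaker inhibitor), and in that assay compound 2 gives 17200 nM. Compound 1 `O=c1[nH]cc(S(=O)(=O)Nc2ccccc2-c2cn(-c3cccc(F)c3)nn2)c(=O)[nH]1` reaches only a limit of the assay and is recorded as > 20000 nM. Compound 3 `Cc1cccc(-n2cc(-c3cccc(NS(=O)(=O)c4c[nH]c(=O)[nH]c4=O)c3)nn2)c1` differs from compound 2 by methyl in place of hydrogen on an aromatic carbon, in other words methyl in place of hydrogen on an aromatic carbon. No measured step of this kind exists among these compounds. The change is expected to move potency little, a 1.1-fold lower number from compound 2 to compound 3 (0.06 log units; within the scatter), in neither direction beyond the usual scatter. Compound 3 is estimated at 15000 nM, with a range from 6000 nM to 40000 nM.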

Compound 3, half-maximal inhibitory concentration: 9100 nM
Compound 3: the middle estimate sits 1.6-fold (0.22 log units) above what was measured; the range from low to high includes it.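

In this assay, among the compounds shown here, this is the first measured step at this position: methyl in place of hydrogen on an aromatic carbon gives a 1.9-fold lower number from compound 2 to compound 3 (0.28 log units; within the scatter). The phenyl to 3-methylphenyl change thus stays within the scatter, and compound 3, like compound 2, gives a number. Compound 1 carries a limit and not a number: the limit of > 20000 nM in this assay, at which 1 of the 3 values shown sits. As far as these compounds go, whether another group at this place, such as an amine, a carboxylic acid or a longer chain, would move the value beyond the scatter stays open.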